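The compounds below may be only part of what the source reports. "The series", "measured", "known", "first", "only" and "open" are said of these compounds alone.

Values in an ADME assay on KB cells (Homo sapiens) for cytotoxicity, read by MTT assay, with a stated time of 72 h; a lower number here means a stronger inhibitor, a higher number a weaker inhibitor:
compound 1 `COc1ccc(OC)c(C2=C(c3cc(OC)c(OC)c(OC)c3)C(=O)CC2O[SiH2]C(C)(C)C)c1`: 10 ug/mL
compound 2 `COC(=O)c1cc(C2=C(c3cc(OC)c(OC)c(OC)c3)C(=O)CC2O[SiH2]C(C)(C)C)ccc1OC`: > 100 ug/mL (a limit, not a number)
compound 3 `COc1cc(C2=C(c3ccccc3)C(O[SiH2]C(C)(C)C)CC2=O)cc(OC)c1OC`: > 100 ug/mL (a limit, not a number)

Compound 3 therefore gives no exact number, only the limit > 100 ug/mL. Compound 4 `COc1ccc(C2=C(c3cc(OC)c(OC)c(OC)c3)C(=O)CC2O[SiH2]C(C)(C)C)cc1O` differs from it by one group: 3-hydroxy-4-methoxyphenyl in place of phenyl on a double-bonded ring carbon. The best guides are the two measured steps that change the group on this same ring carbon. Both an at least 10-fold higher number from compound 1 to compound 3 (1.00 log units; beyond the scatter) and an at least 10-fold higher number from compound 1 to compound 2 (1.00 log units; beyond the scatter) lie beyond the scatter, so the choice of group here clearly matters. Compound 1 reaches a measured number, 10 ug/mL, which shows that a ring with added groups can work at this place. Compound 2 goes against any general rule, as its ring also carries added groups. Its > 100 ug/mL is a limit. A gain is thus expected, though with wide doubt. The expected change is an at least 20-fold lower number from compound 3 to compound 4 (1.30 log units; beyond the scatter), towards a lower number. Compound 4 is estimated at 5 ug/mL, with an expected range from 0.5 ug/mL to 50 ug/mL.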

Compound 4, half-maximal inhibitory concentration: 6.5 ug/mL
Estimate against measurement, compound 4: 1.3-fold (0.11 log units) below, within the range that was stated.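

In this assay, 3-hydroxy-4-methoxyphenyl in place of phenyl gives an at least 15-fold lower number from compound 3 to compound 4 (1.18 log units; beyond the scatter), and hydroxy in place of methoxycarbonyl on an aromatic carbon gives an at least 15-fold lower number from compound 2 to compound 4 (1.18 log units; beyond the scatter), so one changed group on this ring separates a compound held at a limit from one with a measured number. Within the data shown here, compound 1 is no longer the only compound with a measured number, and the step to the new ring, a 1.5-fold lower number from compound 1 to compound 4 (0.19 log units; within the scatter), shows that 2,5-dimethoxyphenyl and 3-hydroxy-4-methoxyphenyl cannot be told apart here. Compound 2 and compound 3 each stand at a limit, so the step between them cannot be read: the limit of > 100 ug/mL in this assay, at which 2 of the 4 values shown sit.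

From the compounds shown here alone, it remains open whether the hydroxy group alone accounts for the difference from compound 3, since the methoxy group enters with it. Going by these compounds, how an amine or a carboxylic acid on that aromatic carbon would read also stays unknown.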